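Swapping Dichlorophenyl for Methoxyphenyl on a Shared Core

The source may hold more compounds than are shown below. What is called first, only, known or untested is meant among the compounds shown, and "the series" means these compounds.

Compound 1 `Nc1cc(N)c2nc(-c3ccccc3)c(NCc3ccc(Cl)c(Cl)c3)nc2c1` was tested in a functional assay on U-251 cells (Homo sapiens) for inhibition, read by sulforhodamine B assay, with a stated time of 48 h; a lower number here means that less compound is tolerated, a higher number that more compound is tolerated. In this assay compound 1 gives < 100000 nM, which is a limit of the assay rather than a number. Compound 2 `CCOC(=O)[C@H](CCC(=O)O)NC(=O)c1ccc(Oc2nc3cc(N)cc(N)c3nc2-c2ccccc2)cc1` shares the core of compound 1. In this assay compound 2 gives < 100000 nM, again a limit. Both known values therefore sit at the limit of < 100000 nM in this assay, at which 2 of the 2 values shown sit, and compound 1 stands nowhere more definite than that. Compound 3 `COc1ccc(CNc2nc3cc(N)cc(N)c3nc2-c2ccccc2)cc1` carries 4-methoxyphenyl in place of 3,4-dichlorophenyl on a saturated chain carbon bound to a nitrogen on an aromatic ring. Without a measured step to lean on, the expected change is a step that the limit leaves unreadable from compound 1 to compound 3, with no clear direction. For compound 3 the estimate is 30000 nM, ranging from 3000 nM to 100000 nM.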

Compound 3, concentration lethal to 50% of the cells: 51300 nM
Compound 3: the middle estimate sits 1.7-fold (0.23 log units) below what was measured; the measured number falls inside the stated range.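

The step from compound 1 to compound 3 cannot be read, since the value of compound 1 is only a limit: the limit of < 100000 nM in this assay, at which 2 of the 3 values shown sit.

The compounds shown leave open how far 4-methoxyphenyl in place of 3,4-dichlorophenyl actually shifts the value.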